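The source may report more compounds than this note shows. Statements on the series, on what has been measured and on what is new or still open speak of the compounds shown alone.

In a functional assay on HL-60 cells (Homo sapiens) for antiproliferative activity, read by MTT assay, with a stated time of 48 h (on this read-out higher numbers stand for weaker inhibition and lower numbers for stronger inhibition), compound 2 `Cc1ccc(CN2C(=O)N(c3ccc(Cl)cc3)C(=O)C2CCC(=O)Nc2ccc(C(=O)NO)cc2)cc1` gives 250 nM and compound 1 `O=C(CCC1C(=O)N(c2ccc(Cl)cc2)C(=O)N1Cc1ccc(Br)cc1)Nc1ccc(C(=O)NO)cc1` gives 340 nM, so the two stand level within the usual scatter. Compound 3 `O=C(CCC1C(=O)N(c2ccc(Cl)cc2)C(=O)N1Cc1ccccc1)Nc1ccc(C(=O)NO)cc1` has hydrogen in place of methyl on an aromatic carbon, para to a large group: hydrogen in place of methyl on an aromatic carbon. Among the measured compounds shown here, the one measured step at this place, methyl in place of bromo, is a 1.4-fold lower number from compound 1 to compound 2 (0.13 log units; within the scatter), and it stays within the scatter. A change beyond the scatter is therefore not expected in this assay. The estimated step is a 1.2-fold higher number from compound 2 to compound 3 (0.08 log units; within the scatter). For compound 3 the expected value is 300 nM, with an estimated range of 130 nM to 650 nM.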

Compound 3, half-maximal inhibitory concentration: 610 nM
Compound 3: the middle estimate sits 2.0-fold (0.31 log units) below what was measured, within the range that was stated.
By their numbers in this assay, from the lowest: compounds 2, 1 and 3 (each within the scatter of the next, the first and the last beyond it).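

In this assay, the group at this place on the benzyl ring does count for something: hydrogen in place of methyl gives a 2.4-fold higher number from compound 2 to compound 3 (0.39 log units; beyond the scatter), a modest step and the first here to pass beyond the scatter. Hydrogen in place of bromo gives a 1.8-fold higher number from compound 1 to compound 3 (0.25 log units; within the scatter), which stays within the scatter, so only the step from methyl shows a weakening. Nothing measured here gives a reason for this step. Still open, on these data alone, is where a methoxy group, an amine or a carboxylic acid at this place would fall, and whether a longer chain such as ethyl would hold the value of compound 2.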